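Working notes: amine substituent swap leading to compound 4

The source may hold more compounds than are shown below. What is called first, only, known or untested is meant among the compounds shown, and "the series" means these compounds.

Compound 1 `CN(C)Cc1ccc(NC(=O)Nc2ccc3ncnc(Nc4cccc(C(F)(F)F)c4)c3c2)cc1` gives 1120 nM in a functional assay on A549 cells (Homo sapiens) for antiproliferative activity, read by MTT assay, with a stated time of 72 h; a lower number here means a stronger inhibitor, a higher number a weaker inhibitor. Among the three measured compounds it stands second highest; its nearest neighbour is compound 3 `O=C(Nc1cccc(CN2CCCC2)c1)Nc1ccc2ncnc(Nc3cccc(C(F)(F)F)c3)c2c1`, which gives 860 nM, and the step of a 1.3-fold lower number from compound 1 to compound 3 (0.11 log units; within the scatter). Compound 2 `C#Cc1cccc(Nc2ncnc3ccc(NC(=O)Nc4ccc(CN(CC)CC)cc4)cc23)c1` gives 2250 nM; it differs from compound 1 in two places at once, so its value is read only alongside that of compound 1, and the two lie within the usual scatter of each other.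

Compound 4 `CN1CCN(c2ccc(NC(=O)Nc3ccc4ncnc(Nc5cccc(C(F)(F)F)c5)c4c3)cc2)CC1` differs from compound 1 in one place: 4-methylpiperazin-1-yl in place of (dimethylamino)methyl on an aromatic carbon. Going by the values given here, the only measured step that bears on this change is a 1.3-fold lower number from compound 1 to compound 3 (0.11 log units; within the scatter), which also exchanges the amine-bearing substituent on that phenyl and stays within the scatter. Among the compounds with values here, no measured pair exchanges a chain amine for a ring amine attached directly to the aromatic carbon, so the direction of any effect of the new ring is not anchored by data. On the evidence available, the expectation is a step of no more than the scatter, with no preferred direction.

Compound 4 is therefore expected to give about 1300 nM in this assay, with a range from 500 nM to 3500 nM. This corresponds to an expected step of a 1.2-fold higher number from compound 1 to compound 4 (0.06 log units; within the scatter).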

Compound 4, half-maximal inhibitory concentration: 2760 nM
Beside the measured number, compound 4's estimate is 2.1-fold (0.33 log units) below it; measured number inside the range.
By their numbers in this assay, from the lowest: compounds 3, 1, 2 and 4 (each within the scatter of the next, the first and the last beyond it).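

In this assay, putting 4-methylpiperazin-1-yl in place of (dimethylamino)methyl on an aromatic carbon, para to a large group, gives a 2.5-fold higher number from compound 1 to compound 4 (0.39 log units; beyond the scatter) and so moves the number beyond the scatter. The earlier one-place change on this phenyl, a 1.3-fold lower number from compound 1 to compound 3 (0.11 log units; within the scatter), stayed within the scatter, so the data now show that the choice of amine-bearing group on this ring can shift the number, though this rests on a single modest step from one pair. Nothing available bears on the reason for this step.

Still open, on these data alone, is whether the step goes with the six-membered non-aromatic ring with 2 hetero atoms itself or with the loss of the carbon link, since compound 4 differs from compound 1 in both; a (4-methylpiperazin-1-yl)methyl group on the same aromatic carbon would separate the two. A morpholin-4-yl group at that place would test whether the second ring nitrogen and its methyl group have any part in the step.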